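The source may report more compounds than this note shows. Statements on the series, on what has been measured and on what is new or still open speak of the compounds shown alone.

- Compound 1 `CNC(=O)c1ccc(Sc2ccc(NC(=S)Nc3cccc(C)c3)cc2)nc1` – > 100000 nM
- Compound 2 `CNC(=O)c1ccc(Sc2ccc(NC(=S)Nc3cc(C(F)(F)F)cc(C(F)(F)F)c3)cc2)nc1` – 36100 nM

For the measured compounds named here, in a functional assay on B16-BL6 cells (Mus musculus) for cytotoxicity, read by MTT assay, with a stated time of 48 h (a higher number here means a weaker inhibitor, a lower number a stronger inhibitor), compound 2 gives 36100 nM, the only actual number available so far. For compound 1 the reading of > 100000 nM is a limit of the assay and not a number. Compound 3 `CNC(=O)c1ccc(Sc2ccc(NC(=S)Nc3cccc(C(F)(F)F)c3)cc2)nc1` is derived from compound 2 by one change: hydrogen in place of trifluoromethyl on an aromatic carbon, meta to a trifluoromethyl group (hydrogen in place of trifluoromethyl on an aromatic carbon). Going by the values given here, no measured pair of compounds isolates this change, so the expectation is a cautious one. With compound 2 at 36100 nM as the sole anchor, a modest weakening in this assay seems more likely than a gain. The expected size of the change is a 1.7-fold higher number from compound 2 to compound 3 (0.22 log units; within the scatter), in the direction of weaker inhibition. Compound 3 is estimated at 60000 nM, with an expected range of 30000 nM to 100000 nM.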

Compound 3, half-maximal inhibitory concentration: 53100 nM
Compound 3: middle estimate off by 1.1-fold (0.05 log units), on the high side, within the range that was stated.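

In this assay, for the compounds shown here, hydrogen in place of trifluoromethyl on an aromatic carbon gives a 1.5-fold higher number from compound 2 to compound 3 (0.17 log units; within the scatter) and so, for the first time, this position is read directly: the readings with one and with two trifluoromethyl groups cannot be told apart. Trifluoromethyl in place of methyl on an aromatic carbon gives an at least 1.8-fold lower number from compound 1 to compound 3 (0.27 log units; that floor lies within the scatter) and that floor does not separate the two compounds either. Compound 1 gives a limit of the assay and not a number, so the true size of that step cannot be read: the limit of > 100000 nM in this assay, at which 1 of the 3 values shown sits.

The compounds shown leave open whether an amine, a carboxylic acid or a methoxy group at this position would move the reading beyond the scatter. They also leave open whether changes elsewhere on the shared core would do so.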